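Swapping the Indole Amide of Compound 2 for an Indazole

The source may hold more compounds than are shown below. What is called first, only, known or untested is meant among the compounds shown, and "the series" means these compounds.

Measured so far in a functional assay on HEK293 cells for positive allosteric modulation of metabotropic glutamate receptor 5 (Homo sapiens), read by calcium flux; a higher number here means a larger maximal response, a lower number a smaller maximal response:
compound 1 `O=C(c1ccc(F)c(F)c1)N1CCc2nc(COc3cccc(F)c3)oc2C1` gives 71%
compound 2 `O=C(c1cc2ccccc2[nH]1)N1CCc2nc(COc3ccccc3)oc2C1` gives 40%
compound 3 `Cn1c(C(=O)N2CCc3nc(COc4ccccc4)oc3C2)cc2ccccc21` gives 57%

Compound 2 stands lowest of these three numbers in this assay. Its nearest neighbour is compound 3, reached by a methyl in place of hydrogen on an aromatic nitrogen, which gives a number 17 percentage points higher from compound 2 to compound 3 (beyond the scatter). Compound 1 lies furthest away; what the two values show is that compound 1 gives 71% while compound 2 gives 40%.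

Compound 4 `O=C(c1n[nH]c2ccccc12)N1CCc2nc(COc3ccccc3)oc2C1` has not yet been measured. It differs from compound 2 in one place: 1H-indazol-3-yl in place of 1H-indol-2-yl on a carbonyl carbon. For the measured compounds named here, the only measured step that touches the same amide group is the one from compound 2 to compound 3, and it acts on the ring nitrogen rather than exchanging the ring. Going by the values given here, no measured pair swaps an indole for an indazole, so there is no direct precedent for the size or direction of this change in this assay. The expectation for compound 4 is therefore a step of a number 6 percentage points higher from compound 2 to compound 4 (within the scatter), within or barely beyond the scatter. Compound 4 is estimated at 46%, between 25% and 70%.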

Compound 4, largest response reached (reported as percent of maximum), in percent of the reference or control that the assay uses: 68%
The estimate for compound 4 lay 22 percentage points below the measured number, within the range that was stated.
By their numbers in this assay, from the lowest: compound 2; then compound 3; then compounds 4 and 1 (each within the scatter of the next).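

In this assay, the result shows that this amide position responds to exchanging the ring itself, and not only to the methyl on the aromatic nitrogen: 1H-indazol-3-yl in place of 1H-indol-2-yl on the carbonyl carbon gives a number 28 percentage points higher from compound 2 to compound 4 (beyond the scatter). The two rings have the same count of heavy atoms and the same count of hydrogen-bond donors, and the entering ring adds a second ring nitrogen and a hydrogen-bond acceptor. Nothing available explains the higher number of compound 4.

Going by these compounds, whether a methyl on the ring nitrogen of the 1H-indazol-3-yl group would move the number further, as methyl did on the indole in compound 3, stays open. So does the response in this assay to a carboxylic acid or an amine on the six-membered ring of that group.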